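The compounds below may be only part of what the source reports. "The series", "measured", "known", "first", "only" and "open" are said of these compounds alone.

Compound 1 `Cc1ccc2oc(CSc3nnc(N)s3)cc(=O)c2c1` is one of three related compounds that have been run through a functional assay on MDA-MB-435S cells (Homo sapiens) for cytotoxicity, read by MTT assay, with a stated time of 72 h; on this read-out lower numbers stand for stronger inhibition and higher numbers for weaker inhibition. In this assay compound 1 gives only a limit, > 25000 nM. Compound 2 `Nc1nnc(SCc2cc(=O)c3cc(Cl)ccc3o2)s1`, which carries chloro in place of methyl on an aromatic carbon, likewise gives only a limit in this assay, > 25000 nM. Compound 3 `O=c1cc(CSc2nc3ccccc3o2)c2ccc(O)c(O)c2o1` also returns only a limit in this assay, > 25000 nM. For the measured compounds named here, the one single-point step among them, a step that the two limits leave unreadable from compound 1 to compound 2, cannot be read, since both ends sit at the limit; indeed the limit of > 25000 nM in this assay, at which 3 of the 3 values shown sit, describes the whole measured set, so compound 1 stands nowhere more precisely than at that limit.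

Compound 4 `Cc1ccc2oc(CSc3nnc(C)o3)cc(=O)c2c1` differs from compound 1 at the sulfur whose other neighbours are a saturated chain carbon: 5-methyl-1,3,4-oxadiazol-2-yl in place of 5-amino-1,3,4-thiadiazol-2-yl on a sulfur. Going by the values given here, no measured step touches this ring, so there is no direct evidence on how the change moves cytotoxicity, and the only bearing evidence is the limit of > 25000 nM in this assay, at which 3 of the 3 values shown sit, under which every compound seen so far sits at the limit. Compound 4 is therefore expected to stay in the same weakly active region, with an estimated step that the limit leaves unreadable from compound 1 to compound 4 that is not expected to be resolvable beyond the scatter. The estimate for compound 4 in this assay is 30000 nM, between 8000 nM and 120000 nM.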

Compound 4, half-maximal inhibitory concentration: > 25000 nM
Compound 4: no number, only a limit; the forecaster's own chance of this, stated with the estimate: 75%; the middle value lies beyond the limit too.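

In this assay, for the compounds shown here, compound 4 gives only a limit, > 25000 nM, so the step between compound 1 and compound 4 cannot be read, and no new step emerges. The compounds shown leave open whether either change, chloro for methyl or 5-methyl-1,3,4-oxadiazol-2-yl for 5-amino-1,3,4-thiadiazol-2-yl, moves cytotoxicity at all, and the whole set rests on a single limit: the limit of > 25000 nM in this assay, at which 4 of the 4 values shown sit.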